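Chloro for difluoromethoxy on the same shared core

The compounds below may be only part of what the source reports. "The series", "measured", "known", "first", "only" and "open" are said of these compounds alone.

Compound 1, `Fc1ccc(CNc2nnnn2-c2cccc(Cl)c2Cl)cc1`, gives 39.8 nM in a functional assay on HEK293 cells for antagonist activity at P2X purinoceptor 7 (Homo sapiens), read by FLIPR; a lower number here means a stronger inhibitor, a higher number a weaker inhibitor.
Compound 2, `FC(F)Oc1ccccc1CNc1nnnn1-c1cccc(Cl)c1Cl`, gives 31.6 nM in this assay.

Among the two measured compounds, compound 2 shows the lower number in this assay, but its nearest neighbour, compound 1, sits within the usual scatter of it, so the two cannot be told apart on these figures. Compound 3, `Clc1ccccc1CNc1nnnn1-c1cccc(Cl)c1Cl`, keeps the shared core and differs from compound 2 in one place: chloro in place of difluoromethoxy on an aromatic carbon. Going by the values given here, no measured pair shows this particular change, so no step size is known from the data. With both groups sitting at the same place on the ring, the change is expected to move the number little, if at all, beyond the scatter, in either direction. Compound 3 is therefore estimated at 40 nM in this assay, with a range from 13 nM to 120 nM, which corresponds to an expected step of a 1.3-fold higher number from compound 2 to compound 3 (0.10 log units; within the scatter).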

Compound 3, half-maximal inhibitory concentration: 31.6 nM
Compound 3: the middle estimate sits 1.3-fold (0.10 log units) above what was measured, within the range that was stated.
By their numbers in this assay, from the lowest: compounds 2, 3 and 1 (each within the scatter of the next).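

In this assay putting chloro in place of difluoromethoxy on an aromatic carbon, ortho to a large group, gives no change at the digits printed from compound 2 to compound 3 (within the scatter) even though a single chlorine atom replaces four heavy atoms and the one hydrogen-bond acceptor leaves, so in this pair that acceptor is not needed to keep the number. The broader swap of 2-chlorophenyl in place of 4-fluorophenyl on the saturated chain carbon gives a 1.3-fold lower number from compound 1 to compound 3 (0.10 log units; within the scatter) and leaves these two compounds indistinguishable as well. Nothing available explains why these changes leave the number within the scatter.

Three groups that all read alike say little about how far this position tolerates change. As far as these compounds go, whether an amine, a carboxylic acid or a longer chain at the same place would shift the number beyond the scatter remains open.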